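The source may report more compounds than this note shows. Statements on the series, on what has been measured and on what is new or still open speak of the compounds shown alone.

Compound 1 `O=S(=O)(CC1=NCCS1)c1c(-c2ccccc2)noc1-c1ccccc1`: in a functional assay, read by Griess assay, with a stated time of 150 min, tested at 100 ug/mL (a higher number here means a stronger effect of the compound at the concentration tested, a lower number a weaker effect), compound 1 is reported as "not active" (no number reported). Compound 2 `COc1ccc(C2=NOC(c3ccc(C)cc3)C2S(=O)(=O)CC2=NCCO2)cc1`: compound 2 gives 71.3%. Compound 3 `COc1ccc(C2=NOC(c3ccc(C)cc3)C2S(=O)(=O)CC2=NCCS2)cc1`: compound 3 gives 59.6%.

Compound 2 and compound 3 share one core; compound 1 and the still unmeasured compound 4 `O=S(=O)(CC1=NCCO1)c1c(-c2ccccc2)noc1-c1ccccc1` share another, and the difference between the two cores is not broken down here. Within the first pair the change a group of 5 heavy atoms (3 carbon, 1 nitrogen, 1 oxygen; one five-membered non-aromatic ring with 2 hetero atoms) in place of a group of 5 heavy atoms (3 carbon, 1 nitrogen, 1 sulfur; one five-membered non-aromatic ring with 2 hetero atoms), on a saturated chain carbon bound to a sulfonyl sulfur made a step of a number 11.7 percentage points higher from compound 3 to compound 2 (beyond the scatter). The same change is now made on the second core: a group of 5 heavy atoms (3 carbon, 1 nitrogen, 1 oxygen; one five-membered non-aromatic ring with 2 hetero atoms) in place of a group of 5 heavy atoms (3 carbon, 1 nitrogen, 1 sulfur; one five-membered non-aromatic ring with 2 hetero atoms), on a saturated chain carbon bound to a sulfonyl sulfur. Among the measured compounds shown here, no measured step exists for compound 4, so the estimate stands alone. For the measured compounds named here, because compound 1 is reported as "not active" (no number reported) in this assay, and the one measured step of this kind was only modest, compound 4 is expected to stay weak. Compound 4 is estimated at 12%, with a range from 0% to 30%.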

Compound 4, a percentage reported as activity, at one concentration (the size of the read-out at that concentration, not a potency): 62.1%
Compound 4: middle estimate off by 50.1 percentage points, on the low side, and the stated range ends below it.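

Among the compounds shown here, compound 1 has no number to set against compound 4, so no step between them can be read. The compounds shown leave open how far the oxygen-containing group, in place of the sulfur-containing group, moves the activity on this core. Nothing at hand explains the result of compound 4.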